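Fluorine added to the acid-bearing carbon of compound 2

The compounds below may be only part of what the source reports. "The series", "measured", "known", "first", "only" and "open" are said of these compounds alone.

Measured so far in a functional assay on HEK293 cells for agonist activity at Free fatty acid receptor 1 (Rattus norvegicus), read by FLIPR and calcium flux; on this read-out lower numbers stand for an effect already at smaller amounts and higher numbers for an effect only at larger amounts of compound:
- compound 1, `COc1ccc(F)c([C@H]2CC[C@H](COc3cccc([C@H](C4CC4)[C@H](C)C(=O)O)c3)CC2)c1`, gives 0.4 nM
- compound 2, `COc1ccc(F)c([C@H]2CC[C@H](COc3cccc([C@H](C4CC4)[C@@H](C)C(=O)O)c3)CC2)c1`, gives 4.9 nM
- compound 3, `COc1ccc(F)c([C@H]2CC[C@H](COc3cccc([C@H](C4CC4)[C@@H](F)C(=O)O)c3)CC2)c1`, gives 28 nM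

Compound 2 stands second highest of the three numbers; its nearest neighbour is compound 3, with a 5.7-fold higher number from compound 2 to compound 3 (0.76 log units; beyond the scatter), and the furthest is compound 1, with a 12-fold higher number from compound 1 to compound 2 (1.09 log units; beyond the scatter). Those two steps also frame the open question. The configuration at the acid-bearing carbon matters, as the fact that compounds 1 and 2 differ only in the configuration as drawn shows for the large step from compound 1 to compound 2. Swapping the methyl for fluorine at that carbon, as in the step from compound 2 to compound 3, gave a modest rise in the number.

Compound 4, `COc1ccc(F)c([C@H]2CC[C@H](COc3cccc([C@H](C4CC4)[C@](C)(F)C(=O)O)c3)CC2)c1`, has not yet been measured. It differs from compound 2 by 1-carboxy-1-fluoroethyl in place of 1-carboxyethyl on a saturated chain carbon bound to an aromatic carbon and a saturated ring carbon, so the methyl is kept and fluorine is added at the same carbon. Going by the values given here, the step from compound 2 to compound 3 is the closest precedent and points toward a higher number in this assay; whether keeping the methyl softens or sharpens that shift is not settled by the data. For compound 4 the expected step is a 3.1-fold higher number from compound 2 to compound 4 (0.49 log units; beyond the scatter). Compound 4 is therefore estimated at 15 nM, with a range from 4 nM to 60 nM.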

Compound 4, half-maximal effective concentration: 6.9 nM
For compound 4 the middle estimate is 2.2-fold (0.34 log units) above the measured one; measured number inside the range.
By their numbers in this assay, from the lowest: compound 1; then compounds 2 and 4 (each within the scatter of the next); then compound 3.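

In this assay, 1-carboxy-1-fluoroethyl in place of 1-carboxyethyl leaves no readable change: a 1.4-fold higher number from compound 2 to compound 4 (0.15 log units; within the scatter). With fluorine present, the methyl does count, a 4.1-fold lower number from compound 3 to compound 4 (0.61 log units; beyond the scatter), so among these compounds the earlier rise on going to compound 3 goes with losing the methyl rather than with gaining fluorine. The gap to compound 1 stays, a 17-fold higher number from compound 1 to compound 4 (1.24 log units; beyond the scatter), similar in size to a 12-fold higher number from compound 1 to compound 2 (1.09 log units; beyond the scatter), the step that can be tied to configuration alone: the fact that compounds 1 and 2 differ only in the configuration as drawn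

Still open, from the compounds shown here alone, is whether the opposite configuration of the 1-carboxy-1-fluoroethyl group would come close to compound 1 at 0.4 nM, which would show whether fluorine can be carried in the better configuration as well. Also open is whether a hydroxyl group or a chlorine atom in place of the fluorine would be tolerated in the same way with the methyl kept, since the compounds shown give only one example of such an addition.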